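The source may report more compounds than this note shows. Statements on the series, on what has been measured and on what is new or still open speak of the compounds shown alone.

- compound 1 `COc1ccc(COc2cc(O)c3c(=O)cc(C)oc3c2[C@H]2CCN(C)C[C@H]2O)cc1`: 8%
- compound 2 `Cc1cc(=O)c2c(O)cc(OCc3ccc([N+](=O)[O-])cc3)c([C@H]3CCN(C)C[C@H]3O)c2o1`: 14%

In a functional assay on Caco-2 cells (Homo sapiens) for inhibition, read by MTT assay, with a stated time of 48 h, tested at 10 uM (on this read-out higher numbers stand for more inhibition of growth at the one concentration tested and lower numbers for less inhibition of growth), compound 2 at 14% sits within the scatter of compound 1, so the two cannot be ordered. Compound 3 `Cc1cc(=O)c2c(O)cc(OCc3ccccc3Br)c([C@H]3CCN(C)C[C@H]3O)c2o1` differs from compound 2 by 2-bromophenyl in place of 4-nitrophenyl on a saturated chain carbon bound to an oxygen on an aromatic ring. Among the compounds with values here, the only measured step bearing on this, a number 6 percentage points higher from compound 1 to compound 2 (within the scatter) (nitro in place of methoxy on an aromatic carbon), offers no precedent for a large change, so no step beyond the scatter is expected in this assay here. The estimated step is a number 2 percentage points lower from compound 2 to compound 3 (within the scatter) (an expectation only). Compound 3 is estimated at 12% (expected range 2% to 28%).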

Compound 3, percent growth inhibition at one concentration: 35%
Compound 3: middle estimate off by 23 percentage points, on the low side; measured number above the stated range.
By their numbers in this assay, from the lowest: compounds 1 and 2 (each within the scatter of the next); then compound 3.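

In this assay the group on the saturated chain carbon bound to an oxygen on an aromatic ring can move the read-out beyond the scatter: 2-bromophenyl in place of 4-nitrophenyl gives a number 21 percentage points higher from compound 2 to compound 3 (beyond the scatter) and in place of 4-methoxyphenyl gives a number 27 percentage points higher from compound 1 to compound 3 (beyond the scatter). Compound 1 and compound 2 had shown no such sensitivity, standing within the scatter of each other. Nothing on hand accounts for this gain. Both steps change the substituent and its place on the phenyl together, so the two remain unseparated. Going by these compounds, whether plain benzyl, or an amine on that phenyl, would hold this level remains open.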